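Swapping Methylsulfanyl for Chloro on a Urea Tail

The compounds below may be only part of what the source reports. "The series", "measured", "known", "first", "only" and "open" are said of these compounds alone.

Four compounds share one core. Compound 1 `Cc1cc(NC(=O)Nc2cccc(Cl)c2)c2ccccc2n1`, compound 2 `COC(=O)c1ccc(NC(=O)Nc2cc(C)nc3ccccc23)cc1` and compound 3 `CSc1ccc(NC(=O)Nc2cc(C)nc3ccccc23)cc1` have been measured in an ADME assay on Raji cells (Homo sapiens) for cytotoxicity, with a stated time of 72 h (on this read-out lower numbers stand for an effect already at smaller amounts and higher numbers for an effect only at larger amounts of compound), while compound 4 `Cc1cc(NC(=O)Nc2ccc(Cl)cc2)c2ccccc2n1` has not. In this assay compound 1 gives 18000 nM, and compound 2 gives 17000 nM. For compound 3 this assay reports only a limit, > 25000 nM, not a number. Among the compounds with values here, the only measured step that reaches compound 3 is an at least 1.4-fold higher number from compound 2 to compound 3 (0.16 log units; that floor lies within the scatter). The change now followed is chloro in place of methylsulfanyl on an aromatic carbon. Because compound 3 sits at the limit (the limit of > 25000 nM in this assay, at which 1 of the 3 values shown sits), the size of its step to compound 4 cannot be fixed from its own value, and the step from compound 2 to compound 3 is itself only a floor that lies within the scatter. Compound 1 also carries chloro and gives 18000 nM, so a number of that order is expected for compound 4. The step is therefore expected to be an at least 1.2-fold lower number from compound 3 to compound 4 (0.09 log units; that floor lies within the scatter). Compound 4 is estimated at 20000 nM, with a range from 10000 nM to 40000 nM.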

Compound 4, half-maximal effective concentration: > 25000 nM
Compound 4 gave a limit, no number; the forecaster's own chance of this, stated with the estimate: 40%; middle value at least 1.2-fold (0.09 log units) from the limit.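

In this assay compound 4 gives only a limit, so chloro on an aromatic carbon para to a large group ends at the same limit as methylsulfanyl in that place. The step between these two compounds cannot be read, because both sit at the limit: the limit of > 25000 nM in this assay, at which 2 of the 4 values shown sit.

The steps that can be read are an at least 1.4-fold higher number from compound 2 to compound 4 (0.16 log units; that floor lies within the scatter) for chloro in place of methoxycarbonyl, and an at least 1.3-fold higher number from compound 1 to compound 4 (0.14 log units; that floor lies within the scatter) for 4-chlorophenyl in place of 3-chlorophenyl, so neither shows a difference beyond the scatter.

Going by these compounds, whether an amine or a carboxylic acid in this place would give a number below the limit remains open. On these data alone, the true values of compound 3 and compound 4 also remain open, so it is unknown how far apart these two compounds lie.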